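A few compounds are considered here, and "the series" means these few. Any claim that something is new, unique, unknown or untested is made for them only; others in the source may bear on it.

Compound 1 `CC(C)(C)C(=O)Nc1ccc(-c2cccc(C(=O)N[C@H]3CN[C@@H](C(=O)Nc4ccc(Cl)c(C(F)(F)F)c4)C3)c2)cn1`: 28000 nM
Compound 2 `CC(=O)Nc1ccc(-c2cccc(C(=O)N[C@H]3CN[C@@H](C(=O)Nc4ccc(Cl)c(C(F)(F)F)c4)C3)c2)cn1`: 8710 nM
Compound 3 `Nc1ccc(-c2cccc(C(=O)N[C@H]3CN[C@@H](C(=O)Nc4ccc(Cl)c(C(F)(F)F)c4)C3)c2)cn1`: 20000 nM

In a functional assay on K562 cells (Homo sapiens) for inhibition, read by MTT assay, with a stated time of 48 h (on this read-out higher numbers stand for weaker inhibition and lower numbers for stronger inhibition), compound 3 gives 20000 nM, within the scatter of compound 1: a 1.4-fold lower number from compound 1 to compound 3 (0.15 log units; within the scatter). Compound 2 is separated from it by more than the scatter: a 2.3-fold higher number from compound 2 to compound 3 (0.36 log units; beyond the scatter). Compound 4 `O=C(NC1CC1)c1cncc(-c2cccc(C(=O)N[C@H]3CN[C@@H](C(=O)Nc4ccc(Cl)c(C(F)(F)F)c4)C3)c2)c1` carries 5-(cyclopropylcarbamoyl)pyridin-3-yl in place of 6-aminopyridin-3-yl on an aromatic carbon. Among the compounds with values here, no measured step swaps this whole group. The known steps only alter what sits on its nitrogen, and even a 3.2-fold lower number from compound 1 to compound 2 (0.51 log units; beyond the scatter) is modest, so they give only a weak guide and no clear direction. The expected step in this assay is a 1.4-fold lower number from compound 3 to compound 4 (0.15 log units; within the scatter), none beyond the scatter. For compound 4 the estimated value is 14000 nM, with an expected range of 5000 nM to 40000 nM.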

Compound 4, half-maximal inhibitory concentration: 27300 nM
Estimate against measurement, compound 4: 2.0-fold (0.29 log units) below, within the range that was stated.
By their numbers in this assay, from the lowest: compound 2; then compounds 3, 4 and 1 (each within the scatter of the next).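

In this assay, swapping the whole 6-aminopyridin-3-yl for 5-(cyclopropylcarbamoyl)pyridin-3-yl on this aromatic carbon moves the number only within the scatter: a 1.4-fold higher number from compound 3 to compound 4 (0.14 log units; within the scatter). The 6-acetamidopyridin-3-yl of compound 2 still stands apart, with a 3.1-fold higher number from compound 2 to compound 4 (0.50 log units; beyond the scatter), and compound 2 keeps the lowest number of the four. No measurement here accounts for this difference.

This swap alters both the group on the pyridin-3-yl ring and where it sits, so the two effects cannot be separated. Going by these compounds, whether a carboxylic acid or a morpholine on that ring would go below compound 2 remains open.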